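Halogen variation on the aryl arm: toward compound 4

The source may hold more compounds than are shown below. What is called first, only, known or untested is meant among the compounds shown, and "the series" means these compounds.

Measured so far in a functional assay on HeLa cells (Homo sapiens) for cytotoxicity, read by CCK-8 assay, with a stated time of 72 h; on this read-out higher numbers stand for weaker inhibition and lower numbers for stronger inhibition:
compound 1 `C=CCn1c(=O)/c(=C\c2cccc(Cl)c2)[nH]c(=O)/c1=C\c1ccccc1OC` gives 5500 nM;
compound 2 `C=CCn1c(=O)/c(=C\c2cccc(F)c2)[nH]c(=O)/c1=C\c1ccccc1OC` gives 9100 nM;
compound 3 `C=CCn1c(=O)/c(=C\c2ccccc2Cl)[nH]c(=O)/c1=C\c1ccccc1OC` gives 5100 nM.

Compound 2 holds the highest of the three numbers, but neither step separating it from the others is beyond the scatter: a 1.7-fold higher number from compound 1 to compound 2 (0.22 log units; within the scatter) and a 1.8-fold lower number from compound 2 to compound 3 (0.25 log units; within the scatter). The next compound, compound 4 `C=CCn1c(=O)/c(=C\c2cc(Br)ccc2F)[nH]c(=O)/c1=C\c1ccccc1OC`, differs from compound 2 by 5-bromo-2-fluorophenyl in place of 3-fluorophenyl on a double-bonded chain carbon bound to an aromatic carbon. Going by the values given here, the steps that bear on this are the halogen swap a 1.7-fold higher number from compound 1 to compound 2 (0.22 log units; within the scatter) and the position move a 1.1-fold lower number from compound 1 to compound 3 (0.03 log units; within the scatter), both within the scatter, so no step beyond the scatter is expected in this assay. If anything a number nearer the chloro pair is expected, so that the estimated step is a 1.7-fold lower number from compound 2 to compound 4 (0.22 log units; within the scatter). Compound 4 is therefore estimated at 5500 nM, range 2000 nM to 15000 nM.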

Compound 4, half-maximal inhibitory concentration: 34600 nM
For compound 4 the middle estimate is 6.3-fold (0.80 log units) below the measured one, outside the stated range (above it).
By their numbers in this assay, from the lowest: compounds 3, 1 and 2 (each within the scatter of the next); then compound 4.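

In this assay, this aryl position is not indifferent to substitution: 5-bromo-2-fluorophenyl gives a rise beyond the scatter against each earlier arm (a 3.8-fold higher number from compound 2 to compound 4 (0.58 log units; beyond the scatter); a 6.3-fold higher number from compound 1 to compound 4 (0.80 log units; beyond the scatter); a 6.8-fold higher number from compound 3 to compound 4 (0.83 log units; beyond the scatter)), whereas the steps among compound 1, compound 2 and compound 3 all stayed within it. Compound 4 is also the only one here with two halogens on this ring. No evidence bears on the cause of this step.

From the compounds shown here alone, whether the bromine alone or the two-halogen arrangement carries the step remains open. So does the effect of an amine or a carboxylic acid on this ring.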